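Swapping 4-hydroxybutyl for 4-nitrophenyl on compound 3

The source may report more compounds than this note shows. Statements on the series, on what has been measured and on what is new or still open speak of the compounds shown alone.

In a functional assay on NIH3T3 cells (Mus musculus) (a lower number here means that less compound is needed, a higher number that more compound is needed for the effect), compound 3 `Cn1cncc1C(OCc1ccc(C#N)cc1C#CCCCCO)c1ccc(C#N)cc1` gives 20.9 nM and compound 1 `Cn1cncc1C(OCc1ccc(C#N)cc1/C=C/c1ccccn1)c1ccc(C#N)cc1` gives 23.1 nM as its value, so the two stand level within the scatter. Compound 2 `CCCCCCC#Cc1cc(C#N)ccc1COC(c1ccc(C#N)cc1)c1cncn1C` is reported at > 0.1 nM as a limit only. Compound 4 `Cn1cncc1C(OCc1ccc(C#N)cc1C#Cc1ccc([N+](=O)[O-])cc1)c1ccc(C#N)cc1`, still unmeasured, carries 4-nitrophenyl in place of 4-hydroxybutyl on a triple-bonded carbon. Among the measured compounds shown here, one measured step bears on this with a readable size (a 1.1-fold lower number from compound 1 to compound 3 (0.04 log units; within the scatter)), where 6-hydroxyhex-1-yn-1-yl replaced 2-(pyridin-2-yl)ethenyl on an aromatic carbon. Steps involving compound 2 have no readable size. A similarly small change is therefore expected (a 1.0-fold lower number from compound 3 to compound 4 (0.02 log units; within the scatter)). Compound 4 is estimated at 20 nM in this assay, with an expected range from 5 nM to 80 nM around it.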

Compound 4, half-maximal effective concentration: 36 nM
For compound 4 the middle estimate is 1.8-fold (0.26 log units) below the measured one; the measured number falls inside the stated range.
By their numbers in this assay, from the lowest: compounds 3, 1 and 4 (each within the scatter of the next).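

On this triple-bonded carbon, a 4-nitrophenyl ring can replace the open 4-hydroxybutyl chain without a change beyond the scatter (a 1.7-fold higher number from compound 3 to compound 4 (0.24 log units; within the scatter)). The ethynyl-linked nitrophenyl of compound 4 and the ethenyl-linked pyridine of compound 1 also stand level (a 1.6-fold higher number from compound 1 to compound 4 (0.19 log units; within the scatter)), so this position has now taken chains and rings alike. Steps involving compound 2 cannot be read, because its value is only a limit: the limit of > 0.1 nM in this assay, at which 1 of the 4 values shown sits.

Still open, on these data alone, is whether an amine or a carboxylic acid in place of 4-nitrophenyl would stay level too.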